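Removing the tetramethylbutyl group on two related cores

The compounds below may be only part of what the source reports. "The series", "measured", "known", "first", "only" and "open" are said of these compounds alone.

Compound 1 `CC(C)(C)CC(C)(C)Nc1c(-c2ccc(Br)cc2)nc2ncccn12` and compound 3 `CC(C)(C)CC(C)(C)Nc1nc2ncccn2c1-c1ccc(Br)cc1` are built from the same atoms joined differently; the difference between the two cores is not broken down here. Compound 2 `Nc1c(-c2ccc(Br)cc2)nc2ncccn12` stands to compound 1, and compound 4 `Nc1nc2ncccn2c1-c1ccc(Br)cc1` stands to compound 3, in the same way: hydrogen in place of 1,1,3,3-tetramethylbutyl on a nitrogen on an aromatic ring and hydrogen in place of 1,1,3,3-tetramethylbutyl on a nitrogen on an aromatic ring describe the same change, with the same surroundings at the place where it is made.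

In a toxicity assay on A549 cells (Homo sapiens) for cytotoxicity, read by luminescence and CellTiter-Glo, with a stated time of 48 h (a higher number here means that more compound is tolerated, a lower number that less compound is tolerated), compound 1 gives 32000 nM. Compound 2 reaches only the limit of this assay, > 100000 nM. The step is therefore an at least 3.1-fold higher number from compound 1 to compound 2 (0.49 log units; beyond the scatter), and its full size cannot be told because the limit of > 100000 nM in this assay, at which 2 of the 3 values shown sit, cuts off the upper end. Compound 3 likewise reaches only the limit of this assay, > 100000 nM. So among the three measured compounds only compound 1 gives a number, and the cut-off described by the limit of > 100000 nM in this assay, at which 2 of the 3 values shown sit, holds for the other two.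

Among the measured compounds shown here, for compound 4 the change from compound 3 is the one that moved compound 1 toward the limit, and compound 3 already sits at that limit, so compound 4 is expected to remain there rather than to return to a number. For compound 4 the expected step is a step that the limit leaves unreadable from compound 3 to compound 4. Compound 4 is thus estimated at 150000 nM in this assay, most likely reported as a limit again, with a range of 100000 nM to 300000 nM.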

Compound 4, half-maximal cytotoxic concentration: > 100000 nM
Compound 4 gave a limit, no number; the forecaster's own chance of this, stated with the estimate: 90%; the middle value lies beyond the limit too.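

In this assay compound 3 gives > 100000 nM as a limit. Compound 4 likewise gives > 100000 nM as a limit. No step can be read between compound 3 and compound 4, as both sit at the cut-off: the limit of > 100000 nM in this assay, at which 3 of the 4 values shown sit. Still open, on these data alone, is whether hydrogen in place of 1,1,3,3-tetramethylbutyl changes the result on the core of compound 3 as it does on the core of compound 1.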